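A Methylpiperazine in Place of Methoxy

The source may report more compounds than this note shows. Statements on the series, on what has been measured and on what is new or still open speak of the compounds shown alone.

In a functional assay on MCF7 cells (Homo sapiens) for antiproliferative activity, read by MTT assay, with a stated time of 48 h (a higher number here means a weaker inhibitor, a lower number a stronger inhibitor), compound 1 `COC/C1=C/C[C@](C)(CCC=C(C)C)/C=C/[C@@H](OC(=O)C=C(C)C)[C@](C)(O)/C=C/C1=O` gives 4130 nM and compound 2 `CC(=O)O[C@]1(C)/C=C/C(=O)/C(CO)=C\C[C@](C)(CCC=C(C)C)/C=C/[C@H]1OC(=O)C=C(C)C` gives 2320 nM so the two lie within the scatter of each other. Compound 3 `CC(C)=CCC[C@]1(C)/C=C/[C@@H](OC(=O)C=C(C)C)[C@](C)(O)/C=C/C(=O)/C(CN2CCCC2)=C\C1` gives 220 nM and thus compound 1 stands at the weak end of these numbers. Compound 4 `CC(C)=CCC[C@]1(C)/C=C/[C@@H](OC(=O)C=C(C)C)[C@](C)(O)/C=C/C(=O)/C(CN2CCN(C)CC2)=C\C1` is still unmeasured. Its change from compound 1 is 4-methylpiperazin-1-yl in place of methoxy on a saturated chain carbon bound to a double-bonded ring carbon and one measured step bears on it: pyrrolidin-1-yl in place of methoxy at the same place, a large change beyond the scatter, a 19-fold lower number from compound 1 to compound 3 (1.27 log units; beyond the scatter) in size. With that single guide and a different ring entering, a somewhat smaller drop is expected in this assay with an estimated 9.2-fold lower number from compound 1 to compound 4 (0.96 log units; beyond the scatter) as its size. For compound 4 the estimate is 450 nM with an expected range from 130 nM to 1500 nM pending the measurement.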

Compound 4, half-maximal inhibitory concentration: 550 nM
Beside the measured number, compound 4's estimate is 1.2-fold (0.09 log units) below it, within the range that was stated.
By their numbers in this assay, from the lowest: compound 3; then compound 4; then compounds 2 and 1 (each within the scatter of the next).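

In this assay, 4-methylpiperazin-1-yl on the saturated chain carbon bound to a double-bonded ring carbon gives a 7.5-fold lower number from compound 1 to compound 4 (0.88 log units; beyond the scatter) in place of methoxy, so the fall seen with pyrrolidin-1-yl is not unique to that group. The two amines are not interchangeable here, since a 2.5-fold higher number from compound 3 to compound 4 (0.40 log units; beyond the scatter) separates them in the same assay. Nothing available explains either step.

As far as these compounds go, whether an open-chain amine such as dimethylamino would lower the number at this place remains open. So does the effect of morpholin-4-yl or a carboxylic acid there.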